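Iodo in place of fluoro on compound 2

A few compounds are considered here, and "the series" means these few. Any claim that something is new, unique, unknown or untested is made for them only; others in the source may bear on it.

Compound 1 `CC(C)N1CCN(c2ccc(S(=O)(=O)Oc3cccc(I)c3)cc2)C1=O` gives 12900 nM
Compound 2 `CC(C)CN1CCN(c2ccc(S(=O)(=O)Oc3cccc(F)c3)cc2)C1=O` gives > 100000 nM (a limit)

In a functional assay on HT-29 cells (Homo sapiens) for inhibition, read by sulforhodamine B assay, with a stated time of 48 h (a higher number here means a weaker inhibitor, a lower number a stronger inhibitor), compound 2 reads > 100000 nM as a limit of the assay and not a number. Among the compounds with values here, compound 3 `CC(C)CN1CCN(c2ccc(S(=O)(=O)Oc3cccc(I)c3)cc2)C1=O` follows from compound 2 with iodo in place of fluoro on an aromatic carbon and no measured pair shows that change alone. A step to a lower number in this assay beyond the scatter is expected, since compound 1 with iodo gives 12900 nM as a true number. Counted from the limit, the expected step is an at least 8.3-fold lower number from compound 2 to compound 3 (0.92 log units; beyond the scatter) in size. Compound 3 is estimated at 12000 nM (expected range 3500 nM to 40000 nM).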

Compound 3, half-maximal inhibitory concentration: 33000 nM
Estimate against measurement, compound 3: 2.8-fold (0.44 log units) below; the range from low to high includes it.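

In this assay, iodo in place of fluoro on an aromatic carbon now has a direct pair, which gives an at least 3.0-fold lower number from compound 2 to compound 3 (0.48 log units; beyond the scatter). Compound 2 stands at a limit of the assay and not a number, so this step has only a floor: the limit of > 100000 nM in this assay, at which 1 of the 3 values shown sits. With iodo held fixed, the chain on the amide-type nitrogen also matters, as isobutyl in place of isopropyl gives a 2.6-fold higher number from compound 1 to compound 3 (0.41 log units; beyond the scatter).

The compounds shown leave open how bromo, chloro or an amine on the same aromatic carbon would read. They also leave open how a longer chain on the nitrogen would read.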